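Methoxycarbonyl for methoxy: expectation for compound 3

This account rests on a few compounds, and the source may have more. Where it says the series, first, only, none or still open, it means among the compounds named here.

Compound 1 `Cc1c(C(=O)Nc2ccc(Oc3ncnc4[nH]cc(-c5ccccc5)c34)c(F)c2)c(=O)c2cc(-c3ccccc3)ccc2n1C` carries a phenyl on an aromatic carbon of its fused two-ring system. In an assay on isolated protein for inhibition of tyrosine-protein kinase receptor UFO (Homo sapiens), read by FRET and Z'-LYTE, with a stated time of 1.5 h (a lower number here means a stronger inhibitor, a higher number a weaker inhibitor), compound 1 returns only a limit, > 10000 nM. Compound 2 `COc1ccc2c(c1)c(=O)c(C(=O)Nc1ccc(Oc3ncnc4[nH]cc(-c5ccccc5)c34)c(F)c1)c(C)n2C` has methoxy in place of that phenyl, and in this assay compound 2 gives 99 nM. Going by the values given here, that is the only actual number in the set, the other entry being the limit (the limit of > 10000 nM in this assay, at which 1 of the 2 values shown sits), which makes compound 2 the sole reference point. The step of an at least 100-fold lower number from compound 1 to compound 2 (2.00 log units; beyond the scatter) shows that the choice of group on this aromatic carbon separates a number from a limit.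

Compound 3 `COC(=O)c1ccc2c(c1)c(=O)c(C(=O)Nc1ccc(Oc3ncnc4[nH]cc(-c5ccccc5)c34)c(F)c1)c(C)n2C` differs from compound 2 in one place: methoxycarbonyl in place of methoxy on an aromatic carbon. Among the compounds with values here, only the step from compound 1 to compound 2 bears on it, and that step was large; it too exchanged the group on this aromatic carbon, yet methoxycarbonyl is neither the phenyl of compound 1 nor the methoxy of compound 2, and no further pair informs the direction. A moderate weakening in this assay is expected, a 4.0-fold higher number from compound 2 to compound 3 (0.61 log units; beyond the scatter). Compound 3 is estimated at 400 nM in this assay, within 100 nM to 2500 nM.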

Compound 3, half-maximal inhibitory concentration: > 10000 nM
Compound 3 ended at the assay's limit; the forecaster's own chance of this, stated with the estimate: 15%; middle value at least 25-fold (1.39 log units) away from the limit.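

Notes on the aromatic carbon of the fused two-ring system: exchanging methoxy for methoxycarbonyl gives an at least 100-fold higher number from compound 2 to compound 3 (2.00 log units; beyond the scatter) in this assay, so the earlier loss seen with phenyl is not confined to a group that carries a ring. Of the three groups shown on this carbon, only methoxy gives an actual number, while phenyl and methoxycarbonyl both end at the limit of the assay: the limit of > 10000 nM in this assay, at which 2 of the 3 values shown sit. The step between compound 1 and compound 3 cannot be read, since both values are limits, so phenyl and methoxycarbonyl cannot be ranked against each other.

From the compounds shown here alone, how a hydroxy, an ethoxy, an amine, a carboxylic acid or a primary amide on this aromatic carbon would read in this assay stays open, and with it whether the number depends on the carbonyl of methoxycarbonyl or on the size of the group. Compound 2, at 99 nM, remains the only actual number in the series, so nothing shown tells whether any group on this carbon can give a lower number than methoxy does.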